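Dichlorophenyl in Place of Bromophenyl: Expected Growth Inhibition

The compounds below may be only part of what the source reports. "The series", "measured", "known", "first", "only" and "open" are said of these compounds alone.

Compound 1 `Fc1ccc(C2=NN(C(=S)Nc3ccccc3)C(c3ccc4c(c3)OCCO4)C2)cc1` gives 37600 nM in a functional assay on HT-29 cells (Homo sapiens) for antiproliferative activity, read by MTT assay, with a stated time of 48 h; a lower number here means a stronger inhibitor of growth, a higher number a weaker inhibitor of growth. Compound 2 `CSc1ccc(C2=NN(C(=S)Nc3ccccc3)C(c3ccc4c(c3)OCCO4)C2)cc1`, with methylsulfanyl in place of fluoro on an aromatic carbon, reaches only the limit of this assay, > 200000 nM. That is an at least 5.3-fold higher number from compound 1 to compound 2 (0.72 log units; beyond the scatter). Compound 3 `S=C(Nc1ccccc1)N1N=C(c2ccccc2Br)CC1c1ccc2c(c1)OCCO2` likewise sits at the limit of this assay, > 200000 nM. Within the numbers shown, compound 3 therefore stands at the weak end, together with compound 2, as described by the limit of > 200000 nM in this assay, at which 2 of the 3 values shown sit. Its step from the fluoro compound is an at least 5.3-fold higher number from compound 1 to compound 3 (0.72 log units; beyond the scatter); the step from compound 2 to compound 3 is a step that the two limits leave unreadable from compound 2 to compound 3.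

Compound 4 `S=C(Nc1ccccc1)N1N=C(c2ccc(Cl)c(Cl)c2)CC1c1ccc2c(c1)OCCO2` differs from compound 3 in one place: 3,4-dichlorophenyl in place of 2-bromophenyl on a carbon with a double bond to nitrogen. Among the compounds with values here, no measured step exchanges one halogenated phenyl ring for another halogenated phenyl ring, so only the aryl-ring steps from compound 1 bear on it, and they show that this ring position can move the number by at least a modest amount in either direction. Compound 1 shows that a halogenated phenyl ring here can give a measurable number. Compound 4 is therefore expected to give 70000 nM, between 15000 nM and 250000 nM, which would mean an at least 2.8-fold lower number from compound 3 to compound 4 (0.45 log units; beyond the scatter), though a further limit cannot be ruled out.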

Compound 4, concentration for 50% growth inhibition: 95300 nM
Beside the measured number, compound 4's estimate is 1.4-fold (0.13 log units) below it; the measured number falls inside the stated range.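

The change on the carbon with a double bond to nitrogen now gives a readable gain in this assay over both compounds held at a limit, with an at least 2.0-fold lower number from compound 3 to compound 4 (0.32 log units; beyond the scatter) and with an at least 2.0-fold lower number from compound 2 to compound 4 (0.32 log units; beyond the scatter). A halogenated phenyl ring at this position therefore gives a measurable number in more than one case, yet the result still depends on which ring is present, since 3,4-dichlorophenyl gives a 2.5-fold higher number from compound 1 to compound 4 (0.40 log units; beyond the scatter), while 2-bromophenyl in compound 3 stays at a limit. The step between compound 2 and compound 3 cannot be read, so these two cannot be ranked against each other, and the upper end of the series remains unresolved: the limit of > 200000 nM in this assay, at which 2 of the 4 values shown sit.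

The compounds shown do not separate the kind of halogen from its place on the phenyl ring, and a 4-chlorophenyl or 2-fluorophenyl group would be needed to pull those two changes apart. They also leave open how this position responds to a ring carrying an amine or a carboxylic acid, and whether the fluoro compound's number can be improved on at all.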